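The source may hold more compounds than are shown below. What is called first, only, known or untested is meant among the compounds shown, and "the series" means these compounds.

Compound 1 `OCCOCn1c(SCc2ccccc2)nc2c(Cl)cc(Cl)cc21`: > 100000 nM
Compound 2 `OCCOCn1c(SCc2ccccc2)nc2c(Cl)c(Cl)ccc21`: 35000 nM

Both compounds were tested in a functional assay on KB cells (Homo sapiens) for inhibition; a lower number here means a stronger inhibitor, a higher number a weaker inhibitor. For compound 1 the result is a limit of the assay, not a number: compound 1 reached > 100000 nM without a measured concentration (the limit of > 100000 nM in this assay, at which 1 of the 2 values shown sits). Compound 2, which shares the core, gives 35000 nM in this assay. For the measured compounds named here, with compound 1 known only as a limit, no step between the measured compounds can be sized.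

Compound 3 `OCCOCn1c(S)nc2c(Cl)cc(Cl)cc21` is not yet measured. It differs from compound 1 in one place: hydrogen in place of benzyl on a sulfur. The starting point of this step is itself a limit, so the expectation is that compound 3 also ends at or beyond that limit, with no movement that this assay could resolve. Compound 3 is therefore estimated at 150000 nM, with a range from 40000 nM to 600000 nM. The step this estimate implies is expected to be a step that the limit leaves unreadable from compound 1 to compound 3.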

Compound 3, half-maximal inhibitory concentration: > 100000 nM
Compound 3 was reported as a limit (the forecaster's own chance of this, stated with the estimate: 70%); the middle value lies beyond the limit too.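

In this assay, for the compounds shown here, compound 1 and compound 3 both stand as limits of the assay rather than as numbers, and no step between them can be read. The compounds shown leave open whether hydrogen in place of benzyl on a sulfur changes inhibition in this assay at all, and by how much.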